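Dichlorophenyl Ether in a Carbamate Series at the Limit

A few compounds are considered here, and "the series" means these few. Any claim that something is new, unique, unknown or untested is made for them only; others in the source may bear on it.

Compound 1, `CCC(COc1ccccc1)OC(=O)NCc1ccccc1`, gives > 100000 nM in an assay for inhibition of zeta-carotene desaturase, chloroplastic/chromoplastic (Capsicum annuum), using a Dixon plot, with a stated time of 8 h (on this read-out lower numbers stand for stronger inhibition and higher numbers for weaker inhibition), which is a limit of the assay.
Compound 2, `CCC(COc1cccc(F)c1)OC(=O)NCc1ccccc1`, gives > 100000 nM in this assay, again a limit.
Compound 3, `CCC(COc1cccc(C)c1)OC(=O)NCc1ccccc1`, gives > 100000 nM in this assay, also a limit.

Compound 3 therefore stands only at a limit in this assay, and the two further values shown are limits as well, all three sitting at the limit of > 100000 nM in this assay, at which 3 of the 3 values shown sit. The steps a step that the two limits leave unreadable from compound 1 to compound 2, a step that the two limits leave unreadable from compound 1 to compound 3 and a step that the two limits leave unreadable from compound 2 to compound 3 are each left unreadable by the two limits at their ends, so none of them carries a size or a direction.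

Compound 4, `CCC(COc1ccc(Cl)c(Cl)c1)OC(=O)NCc1ccccc1`, differs from compound 3 by 3,4-dichlorophenyl in place of 3-methylphenyl on an oxygen on a saturated carbon. All three measured steps bear on this change in the sense that they concern substitution on the same aryl ether ring, yet none is readable, so they set neither size nor direction for the step expected in this assay. Compound 4 is expected to give 100000 nM, with a range from 30000 nM to 300000 nM. The step expected, a number no higher from compound 3 to compound 4 (the limit leaves the size open), is none beyond the scatter, and the most likely outcome is that the assay again reports only a limit.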

Compound 4, half-maximal inhibitory concentration: > 100000 nM
Compound 4: a limit, no number (the forecaster's own chance of this, stated with the estimate: 80%); the middle value sits exactly at the limit.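

No new step can be read, since compound 4, like compound 1, compound 2 and compound 3, stands only at a limit in this assay: the limit of > 100000 nM in this assay, at which 4 of the 4 values shown sit.

The compounds shown leave open whether any of them would give a readable number in this assay, and how the phenyl, 3-fluorophenyl, 3-methylphenyl and 3,4-dichlorophenyl groups rank against one another.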